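From methoxy to an arylamino group

A few compounds are considered here, and "the series" means these few. Any claim that something is new, unique, unknown or untested is made for them only; others in the source may bear on it.

In a functional assay on SEM cells (Homo sapiens) for cytotoxicity, with a stated time of 72 h (a higher number here means that more compound is needed for the effect, a lower number that less compound is needed), compound 1 (`C=C[C@@](C)(/C=C/c1ccc(OC)cc1)CCC=C(C)C`) gives > 36600 nM as a limit of the assay, not a number. Compound 2 (`CCOC(=O)/C(C)=C/c1cc(/C=C/[C@](C)(/C=C/c2ccc(OC)cc2)CCC=C(C)C)ccc1O`) gives > 36600 nM as a limit too. Going by the values given here, the series therefore offers no measured step to build on. Compound 3 (`C=C[C@@](C)(/C=C/c1ccc(Nc2ccc(F)c(F)c2)cc1)CCC=C(C)C`) carries (3,4-difluorophenyl)amino in place of methoxy on an aromatic carbon para to a large group. In this assay the expected change is an at least 2.6-fold lower number from compound 1 to compound 3 (0.41 log units; beyond the scatter) toward less compound needed, an uncertain expectation that rests on the structural change alone. For compound 3 the estimate is 14000 nM with an expected range from 3000 nM to 36600 nM and a further result at the limit remains possible.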

Compound 3, half-maximal effective concentration: > 36600 nM
Compound 3: only a limit was reported (the forecaster's own chance of this, stated with the estimate: 40%); at least 2.6-fold (0.41 log units) between middle value and limit.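

Going by these compounds alone, compound 1 and compound 3 both rest at a limit of this assay, so no step between them can be read. The compounds shown leave open whether (3,4-difluorophenyl)amino in place of methoxy changes the read-out at all.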